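The source may hold more compounds than are shown below. What is called first, only, known or untested is meant among the compounds shown, and "the series" means these compounds.

Values so far in a functional assay on MCF7 cells (Homo sapiens) for inhibition, read by CCK-8 assay, with a stated time of 48 h; on this read-out higher numbers stand for weaker inhibition and lower numbers for stronger inhibition:
compound 1 `COc1cc(-c2ccnc3cc(-c4ccc(Cl)cc4)nn23)cc(OC)c1OC` gives 2320 nM
compound 2 `COc1cc(-c2ccnc3cc(-c4ccccc4)nn23)cc(OC)c1OC` gives 254 nM
compound 3 `COc1cc(-c2ccnc3cc(-c4ccc(C(C)=O)cc4)nn23)cc(OC)c1OC` gives 5230 nM

Compound 3 stands highest of the three numbers. The two steps up to it are a 2.3-fold higher number from compound 1 to compound 3 (0.35 log units; beyond the scatter) and a 21-fold higher number from compound 2 to compound 3 (1.31 log units; beyond the scatter), the second of them large. Compound 4 `COc1cc(-c2ccnc3cc(-c4ccc(-c5cnn(C)c5)cc4)nn23)cc(OC)c1OC` carries 1-methyl-1H-pyrazol-4-yl in place of acetyl on an aromatic carbon.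

All three measured steps concern this same carbon. Hydrogen gives the lowest number there, and a 9.1-fold lower number from compound 1 to compound 2 (0.96 log units; beyond the scatter) shows that chloro also stands well above it. For the measured compounds named here, no measured compound has a ring at this place, so the expectation rests on these steps alone and is loose. A modest step towards a lower number is expected in this assay, without a return to the level of compound 2 . The expected change is a 2.6-fold lower number from compound 3 to compound 4 (0.42 log units; beyond the scatter). Compound 4 is estimated at 2000 nM, with an expected range from 300 nM to 9000 nM.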

Compound 4, half-maximal inhibitory concentration: 274 nM
Compound 4: the middle estimate sits 7.3-fold (0.86 log units) above what was measured; measured number outside the range, below it.
By their numbers in this assay, from the lowest: compounds 2 and 4 (each within the scatter of the next); then compound 1; then compound 3.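

Working notes on the series: in this assay, the carbon para to a large group accepts a ring without a penalty, since 1-methyl-1H-pyrazol-4-yl matches hydrogen (a 1.1-fold higher number from compound 2 to compound 4 (0.03 log units; within the scatter)). The same group stands well apart from acetyl (a 19-fold lower number from compound 3 to compound 4 (1.28 log units; beyond the scatter)) and from chloro (an 8.5-fold lower number from compound 1 to compound 4 (0.93 log units; beyond the scatter)), so the earlier pattern of any group at this carbon raising the number does not hold, with compound 4 going against it. Nothing available explains why this ring behaves differently from acetyl and chloro.

As far as these compounds go, it remains open whether the level of compound 4 depends on the pyrazole nitrogens or on the methyl on that ring. Also open, from the compounds shown here alone, is how a phenyl ring, a morpholine ring, an amine or a carboxylic acid at this carbon would compare.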